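Heteroaryl swap at the shared core: compound 3

This account rests on a few compounds, and the source may have more. Where it says the series, first, only, none or still open, it means among the compounds named here.

Measured so far, by compound:
- compound 1 `CCC(C)(C)Cc1c[nH]c(CCc2ccc(-c3cccc(C)n3)cc2)n1` — 102 nM
- compound 2 `CCC(C)(C)Cc1c[nH]c(CCc2ccc(-c3ccc(F)cn3)cc2)n1` — 97 nM

Going by the values given here, in a functional assay on HEK293 cells for agonist activity at Bombesin receptor subtype-3 (Homo sapiens), read by luminescence and calcium flux, with a stated time of 10 min (on this read-out higher numbers stand for an effect only at larger amounts of compound and lower numbers for an effect already at smaller amounts), compound 2 gives 97 nM and so stands at the lowest of the two numbers; its nearest neighbour is compound 1, and the only measured step, a 1.1-fold lower number from compound 1 to compound 2 (0.02 log units; within the scatter), is within the scatter. That step exchanges one six-membered ring with one hetero atom for another of the same kind.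

Compound 3 `CCC(C)(C)Cc1c[nH]c(CCc2ccc(-c3cnsc3)cc2)n1` has not yet been measured. It differs from compound 2 by 1,2-thiazol-4-yl in place of 5-fluoropyridin-2-yl on an aromatic carbon. The measured step bears on this only loosely: it shows that the shared core tolerates a change within the pyridine series without a shift beyond the scatter, but nothing yet speaks to a five-membered ring with two hetero atoms at this place. The expectation is therefore a step of a 1.5-fold higher number from compound 2 to compound 3 (0.19 log units; within the scatter), small and uncertain in direction, possibly toward a higher number. For compound 3 the estimated value in this assay is 150 nM, with an expected range from 50 nM to 500 nM.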

Compound 3, half-maximal effective concentration: 100 nM
For compound 3 the middle estimate is 1.5-fold (0.18 log units) above the measured one; measured number inside the range.
By their numbers in this assay, from the lowest: compounds 2, 3 and 1 (each within the scatter of the next).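

In this assay, the aromatic carbon para to a large group now carries a five-membered aromatic ring with 2 hetero atoms, and the reading holds with a 1.0-fold higher number from compound 2 to compound 3 (0.01 log units; within the scatter) and with a 1.0-fold lower number from compound 1 to compound 3 (0.01 log units; within the scatter). The earlier step covered only an exchange between two pyridine groups, whereas 1,2-thiazol-4-yl differs from 5-fluoropyridin-2-yl in ring size, heavy-atom count, hetero-atom count and acceptor count, and none of these differences taken together carries the number beyond the scatter, so the three compounds cannot be ranked at this place. The data at hand offer no explanation for why such different rings read alike.

As far as these compounds go, all three groups at this place are aromatic rings with hetero atoms, so it remains open whether a carboxylic acid, an aminomethyl group or a saturated ring such as piperidine would give a step beyond the scatter. The shared core is also the same throughout, which leaves open whether this tolerance would persist with a different chain in place of the present alkyl group.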